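The source may hold more compounds than are shown below. What is called first, only, known or untested is meant among the compounds shown, and "the series" means these compounds.

In an assay on HEK293 cells for inhibition of transient receptor potential cation channel subfamily M member 8 (Homo sapiens), read by FLIPR, with stated times of 5 min and 3 min (a higher number here means a weaker inhibitor, a lower number a stronger inhibitor), compound 1 `O=C(c1sc(-c2cccc(F)c2)nc1O)N1CCOC1` gives 5500 nM. Among the compounds shown here this is the only measurement reported as an actual number. Compound 2 `CCOC(=O)c1sc(-c2ccccc2)nc1OC` is reported at > 100000 nM, which is a limit of this assay and not a number; the limit of > 100000 nM in this assay, at which 1 of the 2 values shown sits, is the same limit. Compound 3 `O=C(c1sc(-c2cccc(F)c2)nc1O)N1CCCCCO1` has not yet been tested in this assay. It differs from compound 1 in a single place: a group of 7 heavy atoms (5 carbon, 1 nitrogen, 1 oxygen; one seven-membered non-aromatic ring with 2 hetero atoms) in place of a group of 5 heavy atoms (3 carbon, 1 nitrogen, 1 oxygen; one five-membered non-aromatic ring with 2 hetero atoms), on a carbonyl carbon. Within the data shown here, no pair of measured compounds shows what a change of this kind does, so there is no measured step to lean on. With nothing shown to push the value either way, the step from compound 1 to compound 3 is estimated at a 1.1-fold higher number from compound 1 to compound 3 (0.04 log units; within the scatter), a change that stays within the usual scatter. Compound 3 is therefore expected to give about 6000 nM in this assay, with a likely range from 1500 nM to 25000 nM.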

Compound 3, half-maximal inhibitory concentration: 32 nM
Compound 3: the middle estimate sits 190-fold (2.27 log units) above what was measured; measured number below the stated range.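

In this assay, the group on the carbonyl carbon proves to matter a great deal: placing the seven-membered non-aromatic ring with 2 hetero atoms where the five-membered one stood gives a 170-fold lower number from compound 1 to compound 3 (2.24 log units; beyond the scatter). The earlier compounds shown here offered no measured pair for a change at this place, whereas this pair differs only in that ring, so the whole step belongs to this one replacement. What lies behind the size of the step cannot be said from the measurements given here.

A single pair cannot show whether the number falls steadily as the ring grows or drops only with the seven-membered ring, and a six-membered ring of the same kind on that carbonyl carbon would help to settle this. From the compounds shown here alone, how an open-chain amine such as diethylamine would read in that place also remains open.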